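The source may report more compounds than this note shows. Statements on the series, on what has been measured and on what is new or still open speak of the compounds shown alone.

Measured compounds in a functional assay on the whole organism for activation, with Mus musculus as the target; on this read-out lower numbers stand for an effect already at smaller amounts and higher numbers for an effect only at larger amounts of compound:
- compound 1, `CCSc1nc(N)c2nc(O)n(Cc3ccccc3)c2n1`: 0.1 mg/kg
- compound 2, `CCCCNc1nc(N)c2nc(O)n(Cc3ccccc3)c2n1`: 0.1 mg/kg
- compound 3, `CCOc1nc(N)c2nc(O)n(Cc3ccccc3)c2n1`: 0.3 mg/kg

Compound 1 stands level with compound 2 at the digits shown, and the two of them share the lowest number among the three; compound 3 sits highest. The step from compound 1 to compound 2 is no change at the digits printed from compound 1 to compound 2 (within the scatter), whereas the step to the ethoxy compound is a 3.0-fold higher number from compound 1 to compound 3 (0.48 log units; beyond the scatter), and likewise a 3.0-fold higher number from compound 2 to compound 3 (0.48 log units; beyond the scatter).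

Compound 4, `CCCCSc1nc(N)c2nc(O)n(Cc3ccccc3)c2n1`, differs from compound 1 by ethyl in place of hydrogen on a saturated chain carbon, two bonds along the chain from a sulfur. For the measured compounds named here, none of the measured steps lengthens a chain while keeping the sulfur; the change that bears most closely is that from compound 1 to compound 2, where a longer chain on a different attaching atom left the number unchanged in this assay. The two steps that did move the number both involve the ethoxy group of compound 3, which does not enter here. On that basis the step is expected to be no change at the digits printed from compound 1 to compound 4 (within the scatter), with no change beyond the scatter in either direction.

Compound 4 is therefore estimated at 0.1 mg/kg in this assay, with a likely range from 0.04 mg/kg to 0.3 mg/kg.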

Compound 4, minimum effective dose: 0.3 mg/kg
The estimate for compound 4 lay 3.0-fold (0.48 log units) below the measured number; the range from low to high includes it.
By their numbers in this assay, from the lowest: compounds 1 and 2 (each within the scatter of the next); then compounds 3 and 4 (each within the scatter of the next).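

In this assay, the length of the chain on sulfur proves to count: ethyl in place of hydrogen on a saturated chain carbon, two bonds along the chain from a sulfur, which turns ethylsulfanyl into butylsulfanyl, gives a 3.0-fold higher number from compound 1 to compound 4 (0.48 log units; beyond the scatter). The atom that carries the butyl chain counts as well, since butylsulfanyl in place of butylamino gives a 3.0-fold higher number from compound 2 to compound 4 (0.48 log units; beyond the scatter), while butylsulfanyl in place of ethoxy gives no change at the digits printed from compound 3 to compound 4 (within the scatter). So the earlier agreement between ethylsulfanyl and butylamino does not carry over to butylsulfanyl, and no measurement available here accounts for the difference.

The compounds shown leave open how the number responds to other chains on sulfur: methylsulfanyl, propylsulfanyl or a longer chain such as hexylsulfanyl could show whether the trend continues or where it turns. They also leave open whether the same chain change acts alike on the other attaching atoms, as ethylamino beside butylamino and butoxy beside ethoxy would tell.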